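The compounds below may be only part of what the source reports. "The series", "measured", "known", "first", "only" and "open" are said of these compounds alone.

Measured compounds:
- compound 1, `CCN(Cc1ccccc1)C(=O)C1CCN(S(=O)(=O)c2c[nH]cn2)CC1`, in a functional assay on CHO cells for positive allosteric modulation of muscarinic acetylcholine receptor M5 (Homo sapiens), read by calcium flux (a lower number here means a smaller maximal response, a higher number a larger maximal response), compound 1 gives "not determined" (no result reported)
- compound 2, `CCN(Cc1ccccc1)C(=O)C1CCN(S(=O)(=O)c2ccccn2)CC1`, in this assay compound 2 gives "not determined" (no result reported)
- compound 3, `CCN(Cc1ccccc1)C(=O)C1CCN(S(=O)(=O)c2ccc3cn[nH]c3c2)CC1`, in this assay compound 3 gives 86%

The three measured compounds share a core and differ in the sulfonyl-linked aromatic group. In this assay only compound 3 gives a number, 86%; for compound 1 and compound 2 no result was reported, so nothing can be said about how the sulfonyl aromatic group moves the maximal response within this set. Compound 3 therefore stands alone as the single reference point.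

Compound 4, `CCN(Cc1cccc(C)c1)C(=O)C1CCN(S(=O)(=O)c2ccc3cn[nH]c3c2)CC1`, keeps the whole sulfonyl part of compound 3 and alters only the benzyl group: methyl in place of hydrogen on an aromatic carbon

Among the measured compounds shown here, no pair of measured compounds shows the effect of a methyl on this benzyl ring, so the expected step rests on the size of the change alone. A single methyl on an aromatic carbon is a small addition, and no step beyond the usual scatter of this assay is expected from it. The step from compound 3 to compound 4 is estimated as a number 2 percentage points lower from compound 3 to compound 4 (within the scatter), that is essentially flat. Compound 4 is expected to give 84% in this assay, in the range 65% to 100%.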

Compound 4, largest response reached (reported as percent of maximum), in percent of the reference or control that the assay uses: 78%
Compound 4: the middle estimate sits 6 percentage points above what was measured; the range from low to high includes it.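

In this assay, among the compounds shown here, the change from benzyl to 3-methylbenzyl gives a number 8 percentage points lower from compound 3 to compound 4 (within the scatter) and is the first readable step, and the first one on the benzyl ring rather than the sulfonyl side. A methyl on this aromatic carbon therefore leaves the maximal response within the usual scatter, with compound 4 at 78% in a range comparable to that of its parent. No further data bear on this result.

A single small group at one ring position says nothing about whether a methoxy group, an amine, a carboxylic acid or a longer chain would be accepted there, or about how the other ring carbons behave. Steps involving compound 1 and compound 2 cannot be read, so the role of the sulfonyl aromatic group also stays open.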